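Fluoro for methoxycarbonyl on the trimethoxyanilino series

The compounds below may be only part of what the source reports. "The series", "measured", "known", "first", "only" and "open" are said of these compounds alone.

Two members of this small set have been run in a functional assay on KYSE-450 cells (Homo sapiens) for inhibition, read by MTT assay, with a stated time of 48 h; a higher number here means a weaker inhibitor, a lower number a stronger inhibitor. Compound 1 `COC(=O)c1cc(CNc2cc(OC)c(OC)c(OC)c2)ccc1OC` gives 41100 nM in this assay. Compound 2 `COc1cc(NCc2cccc(O)c2)cc(OC)c1OC` gives 71300 nM in this assay. The gap between compound 1 and compound 2 lies within the scatter of repeated measurements, so the two cannot be ranked against each other.

Compound 3 `COc1ccc(CNc2cc(OC)c(OC)c(OC)c2)cc1F` has not yet been measured. Compared with compound 1 the change is fluoro in place of methoxycarbonyl on an aromatic carbon. Going by the values given here, no step between measured compounds isolates this change, so the expectation rests on the two values shown.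

For compound 3 the expectation is a step from compound 1 that stays within the scatter, a 1.2-fold higher number from compound 1 to compound 3 (0.09 log units; within the scatter), with no direction claimed beyond that. The estimate for compound 3 in this assay is 50000 nM, with a range from 20000 nM to 125000 nM.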

Compound 3, half-maximal inhibitory concentration: 46200 nM
Compound 3: the middle estimate sits 1.1-fold (0.03 log units) above what was measured, and the stated range covers the measured number.
By their numbers in this assay, from the lowest: compounds 1, 3 and 2 (each within the scatter of the next).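

In this assay, replacing methoxycarbonyl with fluoro gives a 1.1-fold higher number from compound 1 to compound 3 (0.05 log units; within the scatter). Going by these compounds alone, this is the first step to isolate this aromatic carbon, ortho to a methoxy group and meta to a large group, and it shows that the exchange of 4 heavy atoms and 2 hydrogen-bond acceptors for a single fluorine leaves the number within the scatter. On this pair, the methoxycarbonyl group is therefore not required to hold the value, and no measurement is available here that would explain the flat step.

From the compounds shown here alone, whether the number also holds with an amine or a carboxylic acid on this carbon remains open. Also open, going by these compounds, is whether a change elsewhere on the core of compound 1 can move the number beyond the scatter.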